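Lengthening the hydroxamate chain on an anilide series

A few compounds are considered here, and "the series" means these few. Any claim that something is new, unique, unknown or untested is made for them only; others in the source may bear on it.

Measured so far, in an assay for binding affinity to histone acetyltransferase KAT2B (Homo sapiens), tested at 25 uM; on this read-out lower numbers stand for weaker stabilisation of the target and higher numbers for stronger stabilisation of the target against heat:
compound 1, `Cc1noc(C)c1-c1cc(OCCCCC(=O)NO)cc(C(=O)c2ccccc2)c1`, gives -7.9 degrees C;
compound 2, `Cc1noc(C)c1-c1cc(OCCCCCCC(=O)NO)cc(C(O)c2ccccc2)c1`, gives 0.35 degrees C;
compound 3, `Cc1noc(C)c1-c1cc(NC(=O)CCCCC(=O)NO)cc(C(=O)c2ccccc2)c1`, gives 0.31 degrees C.

Compound 3 stands second highest of the three numbers. Its nearest neighbour is compound 2, whose value lies within the usual scatter of compound 3, so no order between the two can be claimed. Compound 1 lies far below compound 3, well beyond the scatter. Within the data shown here, compound 1 and compound 2 differ from compound 3 in more than one place, so no single step between measured compounds is available to guide an expectation.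

Compound 4, `Cc1noc(C)c1-c1cc(NC(=O)CCCCCC(=O)NO)cc(C(=O)c2ccccc2)c1`, differs from compound 3 only in the length of the chain that ends in the hydroxamic acid: (hydroxycarbamoyl)methyl in place of hydroxycarbamoyl on a saturated chain carbon, four bonds along the chain from a carbonyl carbon. Among the measured compounds shown here, with no measured step of this kind at hand, the step is expected to be small, in either direction, and not beyond the scatter. The step from compound 3 to compound 4 is expected to be a number 0.29 degrees C higher from compound 3 to compound 4 (within the scatter) in this assay . Compound 4 is therefore estimated at 0.6 degrees C, within a range from -2 degrees C to 3.5 degrees C.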

Compound 4, shift of the target's melting temperature: 0.92 degrees C
Estimate against measurement, compound 4: 0.32 degrees C below, and the stated range covers the measured number.
By their numbers in this assay, from the lowest: compound 1; then compounds 3, 2 and 4 (each within the scatter of the next).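

In this assay, among these compounds, the swap of hydroxycarbamoyl for (hydroxycarbamoyl)methyl on a saturated chain carbon, four bonds along the chain from a carbonyl carbon, provides the first step that can be read in one place: a number 0.61 degrees C higher from compound 3 to compound 4 (within the scatter). At this place, then, the longer chain leaves the two compounds indistinguishable on this read-out, and neither a gain nor a loss in stabilisation can be claimed. No separate measurement is available to explain the size of this step.

Going by these compounds, whether 2-(hydroxycarbamoyl)ethyl or 3-(hydroxycarbamoyl)propyl at the same place would give a step beyond the scatter remains open, as does the result of a carboxylic acid replacing the hydroxamic acid. Compound 1, at -7.9 degrees C, differs from the others in more than one place, so its low number cannot be traced to any single change.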